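This account rests on a few compounds, and the source may have more. Where it says the series, first, only, none or still open, it means among the compounds named here.

Going by the values given here, compound 3 `N[C@H]1CC[C@H](Nc2c(C(=O)NCc3ccc(F)cc3)nc(Br)c3cccnc23)CC1` gives 7000 nM in a functional assay on HCT-116 cells (Homo sapiens) for cytotoxicity, read by MTT assay, with a stated time of 72 h (a higher number here means a weaker inhibitor, a lower number a stronger inhibitor), the lowest of the two numbers known, with compound 2 `CNCCCNc1c(C(=O)NCc2ccc(F)cc2)nc(Br)c2cccnc12` at 9000 nM a step away within the scatter a 1.3-fold lower number from compound 2 to compound 3 (0.11 log units; within the scatter). Compound 1 `O=C(NCc1ccc(F)cc1)c1nc(Br)c2cccnc2c1NCc1ccccc1` reached only the limit > 20000 nM, not a number (the limit of > 20000 nM in this assay, at which 1 of the 3 values shown sits). Compound 4 `C[C@H](Nc1c(C(=O)NCc2ccc(F)cc2)nc(Br)c2cccnc12)c1ccccc1` carries the change (1-phenylethyl in place of 4-aminocyclohexyl on a nitrogen on an aromatic ring). The relevant step runs the other way: replacing benzyl by 4-aminocyclohexyl lowered the number an at least 2.8-fold lower number from compound 1 to compound 3 (0.45 log units; beyond the scatter), and 2-(methylamino)ethyl in place of phenyl likewise did an at least 2.2-fold lower number from compound 1 to compound 2 (0.34 log units; beyond the scatter). Removing the amine again, towards a group resembling benzyl, is therefore expected to raise the number, a 3.6-fold higher number from compound 3 to compound 4 (0.55 log units; beyond the scatter), probably back to the limit. Compound 4 is estimated at 25000 nM, within 9000 nM to 70000 nM.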

Compound 4, half-maximal inhibitory concentration: > 20000 nM
Compound 4 ended at the assay's limit (the forecaster's own chance of this, stated with the estimate: 60%); the middle value lies beyond the limit too.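

With 1-phenylethyl on this nitrogen, a ring is present but no amine, and the change brings an at least 2.8-fold higher number from compound 3 to compound 4 (0.45 log units; beyond the scatter); set against the 3-(methylamino)propyl chain, it brings an at least 2.2-fold higher number from compound 2 to compound 4 (0.34 log units; beyond the scatter). Both compounds with a readable number in this assay carry an amine, while compound 1 and compound 4 carry none. The effect of the added methyl cannot be read from compound 1 to compound 4, since each value is a limit and not a number: the limit of > 20000 nM in this assay, at which 2 of the 4 values shown sit.

Still open, on these data alone, is whether the amine alone accounts for the difference. A plain cyclohexyl without the amine, or a benzyl carrying an aminomethyl group, would help separate the amine from the ring that bears it.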